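A Fluoro to Chloro Exchange on an Aromatic Ring

The compounds below may be only part of what the source reports. "The series", "measured", "known", "first", "only" and "open" are said of these compounds alone.

In a physicochemical assay for lipophilicity, read by HPLC (a lower number here means a more polar compound, a higher number a more lipophilic compound), compound 3 `Cc1ccsc1C(=CCCN(C)C(CO)C(=O)NCc1ccc(F)cc1)c1sccc1C` stands at 6.45 and compound 2 `Cc1ccsc1C(=CCCN(C)C(CO)C(=O)NCc1ccccc1)c1sccc1C` at 6.26 within the scatter of it. Compound 1 `Cc1ccsc1C(=CCCN(C)C(CCN)C(=O)NCc1ccc(Cl)cc1)c1sccc1C` at 5.85 lies lower than compound 3, and that gap is beyond the scatter. So compound 3 sits level with compound 2 and clear of compound 1.

Compound 4 `Cc1ccsc1C(=CCCN(C)C(CO)C(=O)NCc1ccc(Cl)cc1)c1sccc1C` differs from compound 3 in one place, with chloro in place of fluoro on an aromatic carbon, para to a large group (chloro in place of fluoro on an aromatic carbon). For the measured compounds named here, no measured pair shows this exact exchange. Compound 1 carries the same 4-chlorobenzyl group, but it also differs from compound 4 elsewhere, so it cannot isolate the effect of the chloro.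

The closest guide is the exchange of hydrogen for fluoro at this same carbon, which gave a number 0.19 log units higher from compound 2 to compound 3 (within the scatter) and so stayed small. It starts from hydrogen rather than fluoro, which makes it only a loose guide. On that basis a small rise of similar size is expected, and the estimated step is a number 0.25 log units higher from compound 3 to compound 4 (within the scatter) and would probably stay within the scatter. For compound 4 the estimate is 6.7 with an expected range from 6.35 at the low end to 7.05 at the high end.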

Compound 4, partition coefficient: 6.47
Compound 4: the middle estimate sits 0.23 log units above what was measured; measured number inside the range.
By their numbers in this assay, from the lowest: compound 1; then compounds 2, 3 and 4 (each within the scatter of the next).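

In this assay all three groups tried on this aromatic carbon, para to a large group, now stand level: chloro in place of fluoro gives a number 0.02 log units higher from compound 3 to compound 4 (within the scatter) and chloro in place of hydrogen gives a number 0.21 log units higher from compound 2 to compound 4 (within the scatter) so no exchange among hydrogen, fluoro and chloro here separates from the scatter. Compound 4 also gives the first comparison with compound 1 that differs in only one place: hydroxy in place of aminomethyl on the saturated chain carbon gives a number 0.62 log units higher from compound 1 to compound 4 (beyond the scatter) so among these compounds the only step beyond the scatter comes from that chain and not from the aromatic carbon. No measurement shown here explains either the level values at the aromatic carbon or the larger step at the chain.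

The compounds shown leave open whether a bulkier group on the same aromatic carbon, such as trifluoromethyl or methoxy, would give a step beyond the scatter. They also leave open how a carboxylic acid or a longer chain carrying the hydroxy would read in place of the hydroxy on the saturated chain carbon.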